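Swapping tert-butyl for phenyl on an amide nitrogen

A few compounds are considered here, and "the series" means these few. Any claim that something is new, unique, unknown or untested is made for them only; others in the source may bear on it.

Of the compounds shown here, three sharing one core have been tested in a functional assay on SW480 cells (Homo sapiens) for cytotoxicity, read by MTT assay, with a stated time of 24 h; on this read-out higher numbers stand for weaker inhibition and lower numbers for stronger inhibition. Compound 1, `C=CC1=C(C(=O)NC(C)(C)C)C(c2ccc(OC)cc2)OC1`, carries a tert-butyl group on its amide nitrogen. In this assay compound 1 gives > 100000 nM, which is a limit of the assay rather than a number. Compound 2, `C=CC1=C(C(=O)Nc2ccc(OCC)cc2)C(c2ccc(F)cc2)OC1`, is built on the same core with a different amide substituent and a different ring. In this assay compound 2 also gives > 100000 nM, again a limit. Compound 3, `C=CC1=C(C(=O)NCCC)C(c2ccc(F)cc2)OC1`, carries a propyl group on the amide nitrogen. In this assay compound 3 gives > 100000 nM, once more a limit. So compound 1 stands where every measured compound stands: at the limit of > 100000 nM in this assay, at which 3 of the 3 values shown sit, and nothing separates it from the others.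

Compound 4, `C=CC1=C(C(=O)Nc2ccccc2)C(c2ccc(OC)cc2)OC1`, is the next compound to be measured. It differs from compound 1 in one place: phenyl in place of tert-butyl on an amide-type nitrogen. Going by the values given here, no measured pair shows this change, so no size or direction can be read from the existing numbers.

Given that all three measured compounds sit at the limit, compound 4 is expected to land near it as well, with an estimated value of 150000 nM and a range from 50000 nM to 500000 nM. The expected step, a step that the limit leaves unreadable from compound 1 to compound 4, is thus no change beyond the scatter.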

Compound 4, half-maximal inhibitory concentration: > 100000 nM
Compound 4: no number, only a limit; the forecaster's own chance of this, stated with the estimate: 80%; the middle value lies beyond the limit too.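

Going by these compounds alone, compound 4, like compound 1, gives only a limit and not a number, so the swap of tert-butyl for phenyl on the amide nitrogen yields no step that can be read. The compounds shown leave open which change to the shared core, if any, would give a measured number, since every compound sits at the same point: the limit of > 100000 nM in this assay, at which 4 of the 4 values shown sit.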